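This account rests on a few compounds, and the source may have more. Where it says the series, first, only, none or still open, it means among the compounds named here.

Working notes on the series.

Compound 2, `CC(C(=O)NCc1ccc(C(F)(F)F)nc1N(C)c1ccccc1)c1ccc(NS(C)(=O)=O)c(F)c1`, gives 0.9 nM in a functional assay on CHO-K1 cells for antagonist activity at transient receptor potential cation channel subfamily V member 1 (Homo sapiens), read by FLIPR; a lower number here means a stronger inhibitor, a higher number a weaker inhibitor. On the two numbers in hand this is the higher one: its nearest neighbour is compound 1, `CCCN(CCC)c1nc(C(F)(F)F)ccc1CNC(=O)C(C)c1ccc(NS(C)(=O)=O)c(F)c1`, which gives 0.2 nM, and the step of a 4.5-fold higher number from compound 1 to compound 2 (0.65 log units; beyond the scatter) corresponds to methyl(phenyl)amino in place of dipropylamino on an aromatic carbon.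

Compound 3, `CCCCOC1CCN(c2nc(C(F)(F)F)ccc2CNC(=O)C(C)c2ccc(NS(C)(=O)=O)c(F)c2)CC1`, is not yet measured. The change from compound 2 is a group of 11 heavy atoms (9 carbon, 1 nitrogen, 1 oxygen; one six-membered non-aromatic ring with 1 hetero atom) in place of a group of 8 heavy atoms (7 carbon, 1 nitrogen; one six-membered aromatic ring of carbon only), on an aromatic carbon, on an aromatic carbon of a six-membered aromatic ring with 1 nitrogen, next to the ring nitrogen, ortho to a large group and meta to a trifluoromethyl group.

Going by the values given here, the only step that bears on this position is a 4.5-fold higher number from compound 1 to compound 2 (0.65 log units; beyond the scatter), which shows that the group on this carbon moves the number beyond the scatter. Compound 3 returns from an aromatic substituent to a saturated amine, as in compound 1, so for compound 3 a lower number is expected, estimated at 0.4 nM with a range of 0.1 nM to 1.5 nM, i.e. an expected step of a 2.3-fold lower number from compound 2 to compound 3 (0.35 log units; beyond the scatter).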

Compound 3, inhibition constant: 3.5 nM
Estimate against measurement, compound 3: 8.8-fold (0.94 log units) below; measured number outside the range, above it.
By their numbers in this assay, from the lowest: compound 1; then compound 2; then compound 3.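

At this position in this assay, a saturated amine does not by itself keep the number low: an 18-fold higher number from compound 1 to compound 3 (1.24 log units; beyond the scatter) separates two non-aromatic amino groups by a large step. The order also does not follow aromatic against non-aromatic, since a 3.9-fold higher number from compound 2 to compound 3 (0.59 log units; beyond the scatter) leaves the aromatic methyl(phenyl)amino group on the lower side of the group with the six-membered non-aromatic ring, while dipropylamino, with no ring, has the lowest number of the three. No measurement at hand accounts for this order.

The compounds shown do not separate the contribution of the ring from that of the butoxy chain it carries, and a plain piperidine or a methoxy group on the same ring would do so. On these data alone, whether shorter or longer dialkylamino groups, such as dimethylamino or dibutylamino, stay near dipropylamino also remains open.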